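A few compounds are considered here, and "the series" means these few. Any claim that something is new, unique, unknown or untested is made for them only; others in the source may bear on it.

Measured compounds:
Compound 1, `CCCCC[Se]c1nc(NCc2ccc(SC)cc2)c2ccccc2n1`, gives 34700 nM in a functional assay on MCF7 cells (Homo sapiens) for cytotoxicity, read by MTT assay, with a stated time of 72 h; a lower number here means a stronger inhibitor of growth, a higher number a weaker inhibitor of growth.
Compound 2, `CSc1ccc(CNc2nc([SeH])nc3ccccc23)cc1`, gives 48100 nM.
Compound 3, `CCCCC[Se]c1nc(NCc2ccccc2)c2ccccc2n1`, gives 50 nM.

Two changes link these three compounds. The first is hydrogen in place of pentyl on a selenium. This change made a 1.4-fold higher number from compound 1 to compound 2 (0.14 log units; within the scatter), so compound 1 and compound 2 are not told apart by this measurement. The second is hydrogen in place of methylsulfanyl on an aromatic carbon. Here the outcome is quite different: a 690-fold lower number from compound 1 to compound 3 (2.84 log units; beyond the scatter), so compound 3 stands well apart from both compound 1 and compound 2.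

Compound 4, `[SeH]c1nc(NCc2ccccc2)c2ccccc2n1`, has not yet been measured. It differs from compound 3 by hydrogen in place of pentyl on a selenium. This is the same change that was made from compound 1 to compound 2, at the same kind of place, so the earlier step is the natural guide. For the measured compounds named here, the two starting points differ, however: the core of compound 3 and compound 4 lacks the methylsulfanyl group that sits on compound 1 and compound 2, and that is exactly the difference that moved the number so far. Going by these compounds, it is unknown whether the removal of pentyl behaves the same way on this other core.

Going by the values given here, with only one earlier example, the expectation is that compound 4 stays close to compound 3, with the step from compound 3 to compound 4 estimated as a 1.6-fold higher number from compound 3 to compound 4 (0.20 log units; within the scatter), because the step of a 1.4-fold higher number from compound 1 to compound 2 (0.14 log units; within the scatter) stayed within the scatter. Compound 4 is therefore estimated at 80 nM, with a range from 25 nM to 400 nM that leaves room for the change to matter more on this core than it did before.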

Compound 4, concentration for 50% growth inhibition: > 100000 nM
Compound 4 ended at the assay's limit; the forecaster's own chance of this, stated with the estimate: 0%; middle value at least 1200-fold (3.09 log units) away from the limit.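

In this assay compound 4 gives > 100000 nM, which is a limit of the assay and not a number, so any step to it gives only a minimum size. Hydrogen in place of pentyl on a selenium gave an at least 2000-fold higher number from compound 3 to compound 4 (3.30 log units; beyond the scatter), so a step that stayed within the scatter on the core of compound 1 did not carry over to the core of compound 3: the same change on two cores in this assay, a 1.4-fold higher number (0.14 log units; within the scatter) from compound 1 to compound 2 and an at least 2000-fold higher number (3.30 log units; beyond the scatter) from compound 3 to compound 4, at least 1400-fold (3.15 log units) apart, beyond the scatter of two such steps Hydrogen in place of methylsulfanyl on an aromatic carbon, read on the two compounds without pentyl, gave an at least 2.0-fold higher number from compound 2 to compound 4 (0.31 log units; beyond the scatter), and these four compounds show that the outcome of each change depends on the other group present, but not how large the true step is or why the two groups depend on each other: the same change on two cores in this assay, a 690-fold lower number (2.84 log units; beyond the scatter) from compound 1 to compound 3 and an at least 2.0-fold higher number (0.31 log units; beyond the scatter) from compound 2 to compound 4, at least 1400-fold (3.15 log units) apart, beyond the scatter of two such steps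

The compounds shown leave open whether pentyl itself is needed on the selenium, or whether a shorter methyl group, a longer octyl chain or a benzyl group would serve as well. They also leave open whether another group on that aromatic carbon, such as methoxy or chlorine, would raise the number as far as methylsulfanyl did.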